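Replacing Phenyl with Pentyl on a Ring Nitrogen

The source may hold more compounds than are shown below. What is called first, only, known or untested is meant among the compounds shown, and "the series" means these compounds.

Measured compounds:
Compound 1 `Cc1ccc(N2C(=O)C/C(=C\c3cccc(C(=O)Nc4cccc(F)c4)c3)C2=O)cc1` gives in an ADME assay on NCM460 cells (Homo sapiens) for cytotoxicity, read by MTT assay, with a stated time of 72 h (on this read-out lower numbers stand for stronger inhibition and higher numbers for weaker inhibition), a value that is only a limit of the assay, > 100000 nM.
Compound 2 `Cc1cccc(NC(=O)c2cccc(/C=C3\CC(=O)N(c4ccccc4)C3=O)c2)c1` gives in this assay again only a limit, > 100000 nM.
Compound 3 `O=C(Nc1cccc(F)c1)c1cccc(/C=C2\CC(=O)N(c3ccccc3)C2=O)c1` gives in this assay likewise only a limit, > 100000 nM.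

Compound 3 therefore stands at the limit of this assay, and it shares that position with every other measured compound, since (the limit of > 100000 nM in this assay, at which 3 of the 3 values shown sit). Two measured steps lead to compound 3: a step that the two limits leave unreadable from compound 1 to compound 3 and a step that the two limits leave unreadable from compound 2 to compound 3. Both change the other aromatic ring, and both leave their size unreadable. Compound 4 `CCCCCN1C(=O)C/C(=C\c2cccc(C(=O)Nc3cccc(F)c3)c2)C1=O` differs from compound 3 by pentyl in place of phenyl on an amide-type nitrogen in a ring. Among the compounds with values here, no measured step touches this nitrogen, so the steps on hand cannot set a direction; they only show that compound 3 sits at the limit. The expectation for compound 4 in this assay is accordingly a step of about a number no higher from compound 3 to compound 4 (the limit leaves the size open), that is, none beyond the scatter, with the result most likely again reported as a limit. Compound 4 is estimated at 100000 nM, within 30000 nM to 300000 nM.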

Compound 4, half-maximal inhibitory concentration: > 100000 nM
Compound 4 was reported as a limit (the forecaster's own chance of this, stated with the estimate: 80%); the middle value lies on the limit itself.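

The steps to compound 4 from compound 3 and from compound 1 cannot be read, as all four compounds share one limit in this assay: the limit of > 100000 nM in this assay, at which 4 of the 4 values shown sit.

The compounds shown leave open whether either change, on the ring nitrogen or on the other aromatic ring, alters cytotoxicity at all.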